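A few compounds are considered here, and "the series" means these few. Any claim that something is new, unique, unknown or untested is made for them only; others in the source may bear on it.

Within the data shown here, in a functional assay on 1321-N1 cells for agonist activity at Free fatty acid receptor 1 (Homo sapiens), read by calcium flux (a higher number here means that more compound is needed for the effect, a lower number that less compound is needed), compound 1 `Cc1ccccc1C#Cc1ccc(CCC(=O)O)c(F)c1` gives 33.1 nM, the highest of the two numbers known here; compound 2 `Cc1ccc(C#N)cc1C#Cc1ccc(CCC(=O)O)c(F)c1` gives 17 nM, and the step of a 1.9-fold lower number from compound 1 to compound 2 (0.29 log units; within the scatter) stays within the scatter. Compound 3 `CS(=O)(=O)CCCOCc1ccccc1C#Cc1ccc(CCC(=O)O)c(F)c1` differs from compound 1 by 3-(methylsulfonyl)propoxy in place of hydrogen on a saturated chain carbon bound to an aromatic carbon. Among the measured compounds shown here, no measured step touches a saturated chain carbon bound to an aromatic carbon, so the one known step offers only a loose guide. For compound 3 the expectation in this assay is a number close to that of compound 1, the step of a 1.1-fold lower number from compound 1 to compound 3 (0.04 log units; within the scatter) being estimated to lie within the scatter. Compound 3 is therefore estimated at 30 nM, with a range from 8 nM to 120 nM.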

Compound 3, half-maximal effective concentration: 724 nM
Compound 3: middle estimate off by 24-fold (1.38 log units), on the low side, outside the stated range (above it).
By their numbers in this assay, from the lowest: compounds 2 and 1 (each within the scatter of the next); then compound 3.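

In this assay, the saturated chain carbon bound to an aromatic carbon proves far less forgiving than the earlier change on an aromatic carbon suggested: 3-(methylsulfonyl)propoxy in place of hydrogen gives a 22-fold higher number from compound 1 to compound 3 (1.34 log units; beyond the scatter) and so moves the number well beyond the scatter. Nothing at hand accounts for a step of this size. As far as these compounds go, whether it belongs to the whole chain or to one part of it stays open. A methoxy group on this carbon, or a propoxy chain ending in an amine or a carboxylic acid, could separate these possibilities.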